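Formyl to Hydroxy(sulfo)methyl: Cytotoxicity on Vero Cells

The source may hold more compounds than are shown below. What is called first, only, known or untested is meant among the compounds shown, and "the series" means these compounds.

Compound 1 `O=C[C@H](C[C@@H]1CCNC1=O)NC(=O)[C@H](CC1CC1)NC(=O)OCc1ccccc1` and compound 2 `COc1cccc2[nH]c(C(=O)N[C@@H](CC(C)C)C(=O)N[C@H](C=O)C[C@@H]3CCNC3=O)cc12` each carry a formyl group; how their two cores differ is not broken down here. In an ADME assay on Vero C1008 cells (Chlorocebus sabaeus) for cytotoxicity, read by luminescence and CellTiter-Glo, with a stated time of 24 h (on this read-out higher numbers stand for lower toxicity in this test and lower numbers for higher toxicity in this test), compound 1 gives only a limit of the assay, > 200000 nM. In this assay compound 2 likewise gives only a limit, > 200000 nM. Compound 3 `O=C(N[C@@H](CC1CC1)C(=O)N[C@@H](C[C@@H]1CCNC1=O)C(O)S(=O)(=O)O)OCc1ccccc1` arises from compound 1 by hydroxy(sulfo)methyl in place of formyl on a saturated chain carbon bound to an amide-type nitrogen and a saturated chain carbon. In this assay compound 3 again gives only a limit, > 200000 nM. The step that the two limits leave unreadable from compound 1 to compound 3 therefore cannot be sized, because of the limit of > 200000 nM in this assay, at which 3 of the 3 values shown sit.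

Compound 4 `COc1cccc2[nH]c(C(=O)N[C@@H](CC(C)C)C(=O)N[C@@H](C[C@@H]3CCNC3=O)C(O)S(=O)(=O)O)cc12` is not yet measured. It arises from compound 2 by hydroxy(sulfo)methyl in place of formyl on a saturated chain carbon bound to an amide-type nitrogen and a saturated chain carbon, the same change as from compound 1 to compound 3, at a place described in the same words. The step that the limit leaves unreadable from compound 2 to compound 4 is expected to be flat, resting on the unsized step from compound 1 to compound 3 and on the limit that compound 2 itself shows in this assay. On this basis compound 4 is estimated to give 250000 nM in this assay, with a range from 100000 nM to 600000 nM.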

Compound 4, half-maximal cytotoxic concentration: > 200000 nM
Compound 4: only a limit was reported; the forecaster's own chance of this, stated with the estimate: 85%; the middle value lies beyond the limit too.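

No new step can be read from compound 2 to compound 4, because neither gives a number, only a limit: the limit of > 200000 nM in this assay, at which 4 of the 4 values shown sit. The compounds shown leave open at what concentration, if any, each of the four would reach its half-maximal cytotoxic concentration in this assay, and whether hydroxy(sulfo)methyl in place of formyl changes that concentration at all.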